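The source may report more compounds than this note shows. Statements on the series, on what has been measured and on what is new or still open speak of the compounds shown alone.

Measured in an ADME assay on MDBK cells (Bos taurus) for cytotoxicity, read by MTT assay, with a stated time of 96 h; a higher number here means that more compound is tolerated, a lower number that less compound is tolerated:
- Compound 1 `CC(=O)c1ccc2[nH]c(-c3ccccc3)nc2c1`: > 100000 nM, a limit.
- Compound 2 `CC(=O)c1ccc2[nH]c(-c3ccc(Cl)cc3)nc2c1`: > 100000 nM, a limit.
- Compound 3 `C/C(=N\O)c1ccc2[nH]c(-c3ccccc3)nc2c1`: > 100000 nM, a limit.

Compound 3 has only a limit and no number, and it shares that position with the other two: the limit of > 100000 nM in this assay, at which 3 of the 3 values shown sit.

Compound 4 `C/C(=N\O)c1ccc2[nH]c(-c3ccc(Cl)cc3)nc2c1` follows from compound 3 with chloro in place of hydrogen on an aromatic carbon, para to a large group.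

The same exchange is measured as a step that the two limits leave unreadable from compound 1 to compound 2. The other measured step is a step that the two limits leave unreadable from compound 1 to compound 3. Neither gives a readable size, so no step beyond the scatter is expected in this assay.

The expected change is a number no higher from compound 3 to compound 4 (the limit leaves the size open).

For compound 4 the estimate is 100000 nM, with an expected range of 50000 nM to 200000 nM.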

Compound 4, half-maximal cytotoxic concentration: 37000 nM
Compound 4: the middle estimate sits 2.7-fold (0.43 log units) above what was measured; the whole stated range lies above it.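

In this assay, chloro on the aromatic carbon para to a large group now gives a readable step, an at least 2.7-fold lower number from compound 3 to compound 4 (0.43 log units; beyond the scatter), whereas the same exchange on the core of compound 1 could not be read. With chloro in place, the group of 4 heavy atoms in place of the group of 3 heavy atoms also gives a readable step, an at least 2.7-fold lower number from compound 2 to compound 4 (0.43 log units; beyond the scatter). Only the two changes together leave the limit, and compound 4 alone carries a number: the limit of > 100000 nM in this assay, at which 3 of the 4 values shown sit.

Going by these compounds, the full sizes of both steps stay open, since each starts from a limit. On these data alone, whether fluoro, bromo or methoxy in the place of chloro would give a similar step also stays open.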